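The compounds below may be only part of what the source reports. "The series", "measured", "known", "first", "only" and "open" are said of these compounds alone.

Measured so far:
- compound 1, `CC1=C(CCC(=O)OCCCCOc2no[n+]([O-])c2S(=O)(=O)c2ccccc2)C(=O)c2c(O)cccc2C1=O`, gives 1240 nM in a functional assay on MDA-MB-231 cells (Homo sapiens) for inhibition, read by MTT assay, with a stated time of 72 h; a lower number here means a stronger inhibitor, a higher number a weaker inhibitor
- compound 2, `CC1=C(C(C)CC(=O)OCC(C)COc2no[n+]([O-])c2S(=O)(=O)c2ccccc2)C(=O)c2c(O)cccc2C1=O`, gives 2110 nM in this assay
- compound 3, `CC1=C(CCCC(=O)OCCOc2no[n+]([O-])c2S(=O)(=O)c2ccccc2)C(=O)c2c(O)cccc2C1=O`, gives 1520 nM in this assay

Compound 2 carries the highest of the three numbers in this assay; compound 3 stands nearest and compound 1 furthest, yet both gaps lie within the usual scatter, so no order among the three can be read from these numbers. The three share the same core and differ only in the saturated linker between the ester and the ether oxygen.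

Compound 4, `CC1=C(C(C)CC(=O)OCCCOc2no[n+]([O-])c2S(=O)(=O)c2ccccc2)C(=O)c2c(O)cccc2C1=O`, has not been measured. It differs from compound 2 by hydrogen in place of methyl on a saturated chain carbon bound to two saturated chain carbons. For the measured compounds named here, no step between measured compounds isolates this change. Compound 1 at 1240 nM and compound 3 at 1520 nM also carry no such methyl on the chain and stay within the scatter of compound 2, so no shift beyond the scatter is expected here. The step of a 1.2-fold lower number from compound 2 to compound 4 (0.09 log units; within the scatter) is expected to be small, inside the scatter, in either direction. Compound 4 is therefore estimated at 1700 nM in this assay, with a range from 850 nM to 3400 nM.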

Compound 4, half-maximal inhibitory concentration: 2420 nM
Compound 4: middle estimate off by 1.4-fold (0.15 log units), on the low side, and the stated range covers the measured number.
By their numbers in this assay, from the lowest: compounds 1, 3, 2 and 4 (each within the scatter of the next).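

For the compounds shown here, this is the first step that isolates one change, hydrogen in place of methyl on a saturated chain carbon bound to two saturated chain carbons. In this assay the step (a 1.1-fold higher number from compound 2 to compound 4 (0.06 log units; within the scatter)) stays within the scatter, so removing this methyl leaves no readable shift in the number, and neither compound can be ranked above the other. No measurement available here offers an explanation for this result.

From the compounds shown here alone, the pair speaks only to methyl and hydrogen at this one carbon, so whether an amine, a hydroxyl group or a longer chain there would give a step beyond the scatter stays open. Going by these compounds alone, the other chain methyl, shared by compound 2 and compound 4, also has no step of its own.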